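Isopropylamino in Place of Butylamino on the Shared Core

The source may report more compounds than this note shows. Statements on the series, on what has been measured and on what is new or still open speak of the compounds shown alone.

In a functional assay on HeLa cells (Homo sapiens) for antiproliferative activity, read by WST assay, with a stated time of 24 h (on this read-out higher numbers stand for weaker inhibition and lower numbers for stronger inhibition), compound 1 `C=C[C@]1(C)CC[C@@H](C(=C)COC)C[C@H]1C(=C)C` gives 212000 nM. Compound 2 `C=C[C@]1(C)CC[C@@H](C(=C)CN(CC)CC)C[C@H]1C(=C)C` gives 14400 nM, and compound 3 `C=C[C@]1(C)CC[C@@H](C(=C)CNCCCC)C[C@H]1C(=C)C` gives 10800 nM, the lowest of the three numbers, though its gap to compound 2 lies within the scatter. The large steps both start from the methoxy compound: a 15-fold lower number from compound 1 to compound 2 (1.17 log units; beyond the scatter) and a 20-fold lower number from compound 1 to compound 3 (1.29 log units; beyond the scatter). Between the two amines the step is small: a 1.3-fold lower number from compound 2 to compound 3 (0.12 log units; within the scatter). Compound 4 `C=C[C@]1(C)CC[C@@H](C(=C)CNC(C)C)C[C@H]1C(=C)C` differs from compound 3 by isopropyl in place of butyl on an amine nitrogen. Among the compounds with values here, the only step that bears on this is the exchange of one amine substituent for another, which stayed within the scatter, so compound 4 is expected to show a 1.1-fold higher number from compound 3 to compound 4 (0.05 log units; within the scatter), no more than the scatter. Compound 4 is therefore estimated at 12000 nM, within 6000 nM to 25000 nM.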

Compound 4, half-maximal inhibitory concentration: 40 nM
Compound 4: the middle estimate sits 300-fold (2.48 log units) above what was measured; measured number outside the range, below it.
By their numbers in this assay, from the lowest: compound 4; then compounds 3 and 2 (each within the scatter of the next); then compound 1.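

The amine substituent at this position proves far from interchangeable: isopropyl in place of butyl on an amine nitrogen gives (a 270-fold lower number from compound 3 to compound 4 (2.43 log units; beyond the scatter)), although the butylamino and diethylamino compounds had stayed within the scatter of each other. Isopropylamino also stands well apart from the other two groups (a 360-fold lower number from compound 2 to compound 4 (2.56 log units; beyond the scatter); a 5300-fold lower number from compound 1 to compound 4 (3.72 log units; beyond the scatter)). Nothing measured here accounts for so large a step from so small a change.

The compounds shown leave open whether branching or chain length carries the step. A propylamino, tert-butylamino or cyclopropylamino group in the same place would bear on that.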